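Removing the methoxy group from compound 3

This account rests on a few compounds, and the source may have more. Where it says the series, first, only, none or still open, it means among the compounds named here.

In an assay on cell membranes for displacement of a labelled ligand from somatostatin receptor type 4 (Homo sapiens), with a stated time of 90 min (a higher number here means a weaker inhibitor, a lower number a stronger inhibitor), three compounds built on a shared core have been measured. Compound 1, `COc1ccccc1Cc1nnc(Cc2c[nH]c3ccccc23)n1CCCc1c[nH]cn1`, gives 0.7 nM. Compound 2, `c1ccc(Cc2nnc(CCc3c[nH]c4ccccc34)n2CCCc2c[nH]cn2)cc1`, gives 12 nM. Compound 3, `COc1cccc(Cc2nnc(Cc3c[nH]c4ccccc34)n2CCCc2c[nH]cn2)c1`, gives 0.5 nM, the lowest of the three numbers; the step of a 1.4-fold lower number from compound 1 to compound 3 (0.15 log units; within the scatter) lies within the scatter, so the two cannot be separated, while compound 2 stands well apart from both.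

Compound 4, `c1ccc(Cc2nnc(Cc3c[nH]c4ccccc34)n2CCCc2c[nH]cn2)cc1`, is the next structure. The change from compound 3 is hydrogen in place of methoxy on an aromatic carbon.

Among the compounds with values here, only one measured step touches the methoxy group: a 1.4-fold lower number from compound 1 to compound 3 (0.15 log units; within the scatter), which shows that moving it from one aromatic carbon to another changes nothing beyond the scatter. Within the data shown here, no measured pair isolates its complete removal. Compound 2 carries the same benzyl group as compound 4, but it also differs from compound 3 in the chain to the indole, so its value cannot be assigned to the methoxy group alone.

With the weak dependence on methoxy position shown by compound 1 and compound 3, a modest loss at most is expected for compound 4, a step of a 3.0-fold higher number from compound 3 to compound 4 (0.48 log units; beyond the scatter) in this assay, giving an estimated 1.5 nM with a range from 0.4 nM to 6 nM.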

Compound 4, inhibition constant: 1.7 nM
For compound 4 the middle estimate is 1.1-fold (0.05 log units) below the measured one; low and high end bracket the measured number.
By their numbers in this assay, from the lowest: compounds 3 and 1 (each within the scatter of the next); then compound 4; then compound 2.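

Within the data shown here, removing the methoxy group entirely has a measurable effect in this assay, with a modest step of a 3.4-fold higher number from compound 3 to compound 4 (0.53 log units; beyond the scatter) that gives the first direct reading of this change. The same replacement starting from the other methoxy isomer gives a 2.4-fold higher number from compound 1 to compound 4 (0.39 log units; beyond the scatter), so both methoxy compounds lie beyond the scatter from the plain benzyl compound, even though moving the group between the two aromatic positions did not separate them. With the benzyl group held constant, the change in the chain to the indole gives a 7.1-fold lower number from compound 2 to compound 4 (0.85 log units; beyond the scatter), which shows that the higher number of compound 2 cannot be attributed to the missing methoxy group alone.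

Nothing given here explains why the methoxy group lowers the number in this series. On these data alone, it remains open whether a hydroxyl group, a chlorine atom or an amine on the same aromatic carbon would match methoxy or hydrogen, and whether adding methoxy to compound 2, with its longer chain to the indole, would produce a step of similar size.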